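From Pyrimidin-2-yl to 5-Methyl-1,2-oxazol-3-yl on the Sulfonamide

The source may hold more compounds than are shown below. What is called first, only, known or untested is meant among the compounds shown, and "the series" means these compounds.

Compound 1 `O=S(=O)(Nc1ncccn1)c1ccc(Nc2nncc3ccccc23)cc1`: 7.6 nM
Compound 2 `COc1ccc(NC(=S)NNc2nncc3ccccc23)cc1`: 7.2 nM

Of the compounds shown here, two have been measured in a functional assay on SF-295 cells (Homo sapiens) for antiproliferative activity, read by sulforhodamine B assay, with a stated time of 72 h; on this read-out higher numbers stand for weaker inhibition and lower numbers for stronger inhibition. Compound 1 gives 7.6 nM, and compound 2 gives 7.2 nM. Compound 1 sits at one end of this pair of numbers, but its distance from compound 2 lies within the usual scatter of repeated measurements, so the two read as equal on this read-out. Compound 2 differs from compound 1 in several places at once, so the pair does not isolate any single structural change.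

Compound 3 `Cc1cc(NS(=O)(=O)c2ccc(Nc3nncc4ccccc34)cc2)no1` has not yet been measured. It differs from compound 1 in one place: 5-methyl-1,2-oxazol-3-yl in place of pyrimidin-2-yl on a sulfonamide nitrogen. Among the measured compounds shown here, no measured pair shows what such a swap does here, so the expectation rests on the closeness of the two known values alone. In this assay, only a small step is expected, most likely toward a slightly higher number, but one that may well stay within the scatter; the estimated step is a 1.3-fold higher number from compound 1 to compound 3 (0.12 log units; within the scatter). Compound 3 is thus estimated at 10 nM, with a range from 3 nM to 35 nM.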

Compound 3, half-maximal inhibitory concentration: 4.4 nM
The estimate for compound 3 lay 2.3-fold (0.36 log units) above the measured number, within the range that was stated.
By their numbers in this assay, from the lowest: compounds 3, 2 and 1 (each within the scatter of the next).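

In this assay, putting 5-methyl-1,2-oxazol-3-yl in place of pyrimidin-2-yl on the sulfonamide nitrogen gives a 1.7-fold lower number from compound 1 to compound 3 (0.24 log units; within the scatter), so the two compounds read as equal. Among the compounds shown here, this is the first comparison here that isolates a single structural change, and it shows that a six-membered aromatic ring can give way to a five-membered one at this place with no change that stands out from the scatter, at least for these two groups, which have the same counts of heavy atoms, hydrogen-bond donors and hydrogen-bond acceptors. No supporting data are available to explain this result.

Both groups are aromatic rings with hetero atoms, so the compounds shown leave open whether a plain phenyl ring, a simple methyl group or a longer open chain such as butyl on the same nitrogen would also keep the number in this range. They also leave open whether this equality would hold in other cell lines, since this single pair speaks only for SF-295 cells.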